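The source may hold more compounds than are shown below. What is called first, only, known or untested is meant among the compounds shown, and "the series" means these compounds.

Compound 1 `COc1ccc2[nH]cc(C3(c4c[nH]c5ccc(OC)cc45)C(=O)Nc4ccccc43)c2c1` is one of two compounds tested in a functional assay on HepG2 cells (Homo sapiens) for cytotoxicity, read by MTT assay, with a stated time of 48 h; a higher number here means a weaker inhibitor, a lower number a stronger inhibitor. In this assay compound 1 gives 30200 nM, the higher of the two numbers. Its nearest neighbour, compound 2 `COc1ccc2c(C3(c4c[nH]c5cc(OC)ccc45)C(=O)Nc4ccccc43)c[nH]c2c1`, gives 12000 nM in this assay, a lower number whose gap from compound 1 lies beyond the usual scatter. Compound 3 `COc1ccc2[nH]cc(C3(c4c[nH]c5ccc(OC)cc45)C(=O)Nc4ccc(F)cc43)c2c1` differs from compound 1 by fluoro in place of hydrogen on an aromatic carbon. Within the data shown here, no measured pair shows this change, so the expected step of a 1.4-fold lower number from compound 1 to compound 3 (0.14 log units; within the scatter) is small, with no direction beyond the scatter. Compound 3 is estimated at 22000 nM in this assay, with a range from 7000 nM to 70000 nM.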

Compound 3, half-maximal inhibitory concentration: 36600 nM
The estimate for compound 3 lay 1.7-fold (0.22 log units) below the measured number, within the range that was stated.
By their numbers in this assay, from the lowest: compound 2; then compounds 1 and 3 (each within the scatter of the next).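

In this assay, fluoro in place of hydrogen on this aromatic carbon gives a 1.2-fold higher number from compound 1 to compound 3 (0.08 log units; within the scatter), the first step measured at this position. The position therefore carries fluoro without a change that can be told from the scatter, at least on the core of compound 1. Nothing measured here speaks to what lies behind this result.

On these data alone, whether chloro, an amine or a carboxylic acid on this carbon would move the number stays open. So does whether fluoro would give a similar step on the core of compound 2.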